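This account rests on a few compounds, and the source may have more. Where it says the series, first, only, none or still open, it means among the compounds named here.

Measured so far in an assay on HEK293 cells for displacement of a labelled ligand from 5-hydroxytryptamine receptor 6 (Homo sapiens); on this read-out higher numbers stand for weaker inhibition and lower numbers for stronger inhibition:
- compound 1, `O=C1c2ccccc2S(=O)(=O)N1CCCCCN1CCN(c2ccccc2)CC1`: 1840 nM
- compound 2, `COc1ccccc1N1CCN(CCCCCN2C(=O)c3ccccc3S2(=O)=O)CC1`: 1990 nM
- compound 3, `O=C1c2ccccc2S(=O)(=O)N1CCCCCN1CCN(c2ccccn2)CC1`: 2630 nM

Compound 3 is set apart from neither neighbour: a 1.3-fold higher number from compound 2 to compound 3 (0.12 log units; within the scatter) and a 1.4-fold higher number from compound 1 to compound 3 (0.16 log units; within the scatter) both fall within the scatter, as does a 1.1-fold higher number from compound 1 to compound 2 (0.03 log units; within the scatter). All three numbers therefore sit on one level.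

Compound 4, `O=C1c2ccccc2S(=O)(=O)N1CCCCCN1CCN(c2cccc(C(F)(F)F)c2)CC1`, differs from compound 3 by 3-(trifluoromethyl)phenyl in place of pyridin-2-yl on an amine nitrogen in a ring. Within the data shown here, the steps that bear on the aryl on the ring nitrogen, phenyl to pyridin-2-yl and hydrogen to methoxy on the aromatic carbon, stayed within the scatter, so no step beyond the scatter is expected for a 1.3-fold lower number from compound 3 to compound 4 (0.12 log units; within the scatter) in this assay; the trifluoromethyl group itself has no precedent.

For compound 4 the estimate in this assay is 2000 nM, with a range from 700 nM to 6000 nM.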

Compound 4, inhibition constant: 1350 nM
Beside the measured number, compound 4's estimate is 1.5-fold (0.17 log units) above it, and the stated range covers the measured number.
By their numbers in this assay, from the lowest: compounds 4, 1, 2 and 3 (each within the scatter of the next).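

In this assay the aryl on the ring nitrogen also takes 3-(trifluoromethyl)phenyl with no change of level: a 1.4-fold lower number from compound 1 to compound 4 (0.13 log units; within the scatter) for trifluoromethyl in place of hydrogen, a 1.5-fold lower number from compound 2 to compound 4 (0.17 log units; within the scatter) against 2-methoxyphenyl and a 1.9-fold lower number from compound 3 to compound 4 (0.29 log units; within the scatter) against pyridin-2-yl all lie within the scatter. Trifluoromethyl thus joins methoxy as a substituent on this aryl that moves nothing beyond the scatter. No measurement at hand gives a reason for this flat response.

Still open, on these data alone, is whether any group on this aryl shifts the number beyond the scatter, for instance a carboxylic acid or a primary amine. Also open, as far as these compounds go, is whether a shorter chain to the shared core does so.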